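Methyl for Fluoro on the Sulfonyl Aryl Ring

A few compounds are considered here, and "the series" means these few. Any claim that something is new, unique, unknown or untested is made for them only; others in the source may bear on it.

Compound 1 `CC1CCN(c2c(S(=O)(=O)c3ccc(F)c(F)c3)cnc3cc(F)ccc23)CC1` stands highest of the three numbers measured in an assay on isolated protein for displacement of a labelled ligand from metabotropic glutamate receptor 5 (Homo sapiens), with a stated time of 60 min, tested at 1 uM (on this read-out lower numbers stand for less inhibition and higher numbers for more inhibition at the one concentration tested (going by the name of the read-out)), where compound 1 gives 94%. Nearest to it is compound 3 `CC1CCN(c2c(S(=O)(=O)c3ccc(F)c(F)c3)cnc3cc(Cl)ccc23)CC1`, which in this assay gives 90%; the step of a number 4 percentage points lower from compound 1 to compound 3 (within the scatter) came with chloro in place of fluoro on an aromatic carbon. Furthest away is compound 2 `O=S(=O)(c1ccccc1)c1cnc2ccccc2c1N1CCCCCC1`, which in this assay gives 79.9%, a gap beyond the scatter, though no single change links it to compound 1.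

Compound 4 `Cc1ccc(S(=O)(=O)c2cnc3cc(F)ccc3c2N2CCC(C)CC2)cc1F` has not yet been measured. It differs from compound 1 in one place: methyl in place of fluoro on an aromatic carbon. Among the measured compounds shown here, no measured step swaps fluoro for methyl. For the measured compounds named here, the only step that bears on the question, a number 4 percentage points lower from compound 1 to compound 3 (within the scatter), exchanged one halogen for another on a different ring of the shared core and stayed within the scatter. That is one step on another ring, so it gives only weak guidance. The step expected in this assay is a number 6 percentage points lower from compound 1 to compound 4 (within the scatter), which amounts to none beyond the scatter. Compound 4 is therefore estimated to give 88%, with a range from 72% to 98%.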

Compound 4, a percentage reported as inhibition, at one concentration (the size of the read-out at that concentration, not a potency): 89%
Compound 4: the middle estimate sits 1 percentage points below what was measured, within the range that was stated.
By their numbers in this assay, from the lowest: compounds 2, 4, 3 and 1 (each within the scatter of the next, the first and the last beyond it).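

Changing 3,4-difluorophenyl to 3-fluoro-4-methylphenyl gives a number 5 percentage points lower from compound 1 to compound 4 (within the scatter) in this assay, so at this position, para to a large group, methyl can stand in place of fluoro without a difference that this read-out can separate from the scatter. Among the compounds shown here, the earlier compounds offered only a halogen exchange on the shared core, a number 4 percentage points lower from compound 1 to compound 3 (within the scatter) in the same read-out, whereas this step is the first to touch the sulfonyl aryl ring and the first to replace a halogen with a carbon group, and it too stays within the scatter. Nothing available accounts for the similar numbers of these two compounds.

On these data alone, it remains open whether this position would accept an ethyl or methoxy group, a primary amine or a carboxylic acid as readily as it accepts methyl, and whether the fluoro group that remains on the ring in compound 4 could also be exchanged. With a single tested concentration, the compounds shown also leave open whether compound 1 and compound 4 would differ in a full measure of potency.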